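This account rests on a few compounds, and the source may have more. Where it says the series, first, only, none or still open, it means among the compounds named here.

In a functional assay on PC-3 cells (Homo sapiens) for inhibition, read by CellTiter-Glo, with a stated time of 72 h (a lower number here means that less compound is tolerated, a higher number that more compound is tolerated), compound 2 `CC1=C(CC(=O)N2CCN(CCCN(C)C)CC2)c2cc(F)ccc2/C1=C\c1nc2ccccc2s1` gives 4210 nM. This is the lower of the two numbers available, so less of compound 2 is tolerated by the cells. Compound 1 `CC1=C(CC(=O)N2CCN(c3ccncc3)CC2)c2cc(F)ccc2/C1=C\c1ccc([S+](C)[O-])cc1` gives 21900 nM, and that gap lies beyond the usual scatter of repeated measurements.

The next molecule, compound 3 `CC1=C(CC(=O)N2CCN(c3ccncc3)CC2)c2cc(F)ccc2/C1=C\c1nc2ccccc2s1`, keeps the rest of compound 2 but changes one group: pyridin-4-yl in place of 3-(dimethylamino)propyl on an amine nitrogen in a ring. In words, pyridin-4-yl takes the place of 3-(dimethylamino)propyl on an amine nitrogen in a ring. Compound 3 thus carries the 4-(pyridin-4-yl)piperazin-1-yl group also found in compound 1, which gives 21900 nM.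

Among the measured compounds shown here, no measured pair shows this exchange on its own, so any forecast is uncertain. For the measured compounds named here, the only guide is that the one compound with this group has the higher number, although compound 1 also differs from compound 3 elsewhere. A moderate upward step in this assay is therefore expected, probably beyond the scatter. The estimated step is a 2.1-fold higher number from compound 2 to compound 3 (0.33 log units; beyond the scatter). For compound 3, the expected value is 9000 nM, with an estimated range of 3500 nM to 23000 nM.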

Compound 3, half-maximal cytotoxic concentration: 12300 nM
Beside the measured number, compound 3's estimate is 1.4-fold (0.14 log units) below it, within the range that was stated.
By their numbers in this assay, from the lowest: compound 2; then compounds 3 and 1 (each within the scatter of the next).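

In this assay, among the compounds shown here, the exchange of 3-(dimethylamino)propyl for pyridin-4-yl on an amine nitrogen in a ring gives a 2.9-fold higher number from compound 2 to compound 3 (0.47 log units; beyond the scatter), the first reading of this position with the rest of the molecule held constant. With the 4-(pyridin-4-yl)piperazin-1-yl group held constant, exchanging the group with one six-membered aromatic ring of carbon only for the group with a five-membered and a six-membered aromatic ring, on the double-bonded chain carbon, gives a 1.8-fold lower number from compound 1 to compound 3 (0.25 log units; within the scatter), so this exchange has no effect that can be told apart from the scatter. Nothing measured here explains either result.

As far as these compounds go, because this position is covered by a single pair, it remains open whether the step follows from adding the aromatic ring or from losing the chain with its dimethylamino end. A plain phenyl ring or a shorter chain ending in the same dimethylamino group on that nitrogen would help separate these two readings, and the same exchange with other groups on the double-bonded chain carbon would show how far the step carries over.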